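Nitro replaced by methoxy on the benzyloxy group

A few compounds are considered here, and "the series" means these few. Any claim that something is new, unique, unknown or untested is made for them only; others in the source may bear on it.

Compound 3 `COc1cccc(OC)c1OCCNCCOc1ccccc1OCc1ccc([N+](=O)[O-])cc1` gives 9.02 in a functional assay on spleen for antagonist activity at Alpha-1B adrenergic receptor (Rattus norvegicus) (on this read-out higher numbers stand for higher potency (the scale is a negative logarithm) and lower numbers for lower potency), the highest of the three numbers in hand. Its nearest neighbour is compound 2 `COc1cccc(OC)c1OCCNCCOc1ccccc1OCc1cccc([N+](=O)[O-])c1` with 8.74; the gap a number 0.28 log units higher from compound 2 to compound 3 (within the scatter) lies within the scatter. Compound 1 `COc1cccc(OC)c1OCCNCCOc1ccccc1OCc1cccc(Cl)c1` stands furthest away with 7.93, a gap a number 1.09 log units higher from compound 1 to compound 3 (beyond the scatter) that is beyond the scatter.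

Compound 4 `COc1ccc(COc2ccccc2OCCNCCOc2c(OC)cccc2OC)cc1` differs from compound 3 in one place: methoxy in place of nitro on an aromatic carbon.

Among the compounds with values here, the steps that bear on this are the two that introduce nitro. a number 0.81 log units higher from compound 1 to compound 2 (beyond the scatter) and a number 1.09 log units higher from compound 1 to compound 3 (beyond the scatter) both show that nitro in place of chloro lifts the number well beyond the scatter. Within the data shown here, no measured step shows methoxy at this position, so the size of the return is uncertain; removal of the nitro group is expected to give back part of that gain, with compound 4 landing somewhere between compound 1 and compound 3.

The estimated step is a number 0.72 log units lower from compound 3 to compound 4 (beyond the scatter), a drop beyond the scatter. Compound 4 is therefore expected at 8.3, within 7.6 to 9.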

Compound 4, negative logarithm of the antagonist equilibrium constant: 9.51
Compound 4: the middle estimate sits 1.21 log units below what was measured; the measured number lies above the stated range.
By their numbers in this assay, from the lowest: compound 1; then compounds 2 and 3 (each within the scatter of the next); then compound 4.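

In this assay the change of nitro to methoxy gives a number 0.49 log units higher from compound 3 to compound 4 (beyond the scatter) and so shows that nitro is not required on this aromatic carbon for a high number; the lift seen with nitro over chloro did not mark the top of the range at this place. The 4-methoxyphenyl group also outruns the other two groups on this chain carbon, with a number 0.77 log units higher from compound 2 to compound 4 (beyond the scatter) and a number 1.58 log units higher from compound 1 to compound 4 (beyond the scatter) as the steps, and compound 4 therefore holds the highest number of the four. Nothing in hand accounts for methoxy exceeding nitro here.

Still open, going by these compounds, is whether ethoxy, a longer chain, or an amine on the same aromatic carbon would hold this number. Methoxy is seen at this one place on the ring only, so how far the result depends on that place remains unknown.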